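Swapping an aromatic ring for a saturated one on the ketone

A few compounds are considered here, and "the series" means these few. Any claim that something is new, unique, unknown or untested is made for them only; others in the source may bear on it.

Compound 1 `OB1OCc2ccc(-n3ccc4ccccc43)cc21` is the simplest member of this set. In an ADME assay on L929 cells (Mus musculus) for cytotoxicity, read by resazurin assay, with a stated time of 72 h (on this read-out lower numbers stand for stronger inhibition and higher numbers for weaker inhibition), compound 1 gives only a limit of the assay, > 10 ug/mL. Compound 2 `OB1OCc2ccc(-n3cc(Sc4cccc(Cl)c4)c4ccccc43)cc21` carries a (3-chlorophenyl)sulfanyl in place of hydrogen on an aromatic carbon. In this assay compound 2 also gives a limit, > 10 ug/mL. The step that the two limits leave unreadable from compound 1 to compound 2 is therefore unreadable. Compound 3 `O=C(c1ccc(F)cc1)c1ccn(-c2ccc3c(c2)B(O)OC3)c1` likewise gives a limit in this assay, > 10 ug/mL. What the three values share is the limit of > 10 ug/mL in this assay, at which 3 of the 3 values shown sit. Compound 4 `O=C(c1ccn(-c2ccc3c(c2)B(O)OC3)c1)C1CCCCC1` differs from compound 3 by cyclohexyl in place of 4-fluorophenyl on a carbonyl carbon. For the measured compounds named here, no measured step reads as a number, so no step beyond the scatter is expected in this assay. Compound 4 is estimated to give 20 ug/mL, within 8 ug/mL to 50 ug/mL. The expected step is a step that the limit leaves unreadable from compound 3 to compound 4.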

Compound 4, half-maximal inhibitory concentration: > 10 ug/mL
Compound 4: a limit, no number (the forecaster's own chance of this, stated with the estimate: 80%); the middle value does not contradict the limit.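

In this assay the step from compound 3 to compound 4 cannot be read, as both compounds give only a limit: the limit of > 10 ug/mL in this assay, at which 4 of the 4 values shown sit.

The compounds shown leave open whether any change to the shared core alters cytotoxicity on these cells.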